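Ring halogen pattern against antiproliferative potency in the series

The compounds below may be only part of what the source reports. "The series", "measured", "known", "first", "only" and "open" are said of these compounds alone.

Among the measured compounds shown here, compound 1 `NC1=NC2(CCOCC2)N(OCCCOc2ccc(Cl)c(Cl)c2)C(N)=N1` gives 90 nM in a functional assay on HCT-116 cells (Homo sapiens) for antiproliferative activity, read by MTT assay, with a stated time of 72 h (a higher number here means a weaker inhibitor, a lower number a stronger inhibitor), the second highest of the three numbers so far. Compound 3 `NC1=NC2(CCOCC2)N(OCCCOc2cccc(Br)c2)C(N)=N1` gives 40 nM in this assay, and compound 2 `NC1=NC2(CCOCC2)N(OCCCOc2ccc(F)cc2)C(N)=N1` gives 3280 nM. The measured steps are a 2.3-fold lower number from compound 1 to compound 3 (0.35 log units; beyond the scatter), a 36-fold higher number from compound 1 to compound 2 (1.56 log units; beyond the scatter) and an 82-fold lower number from compound 2 to compound 3 (1.91 log units; beyond the scatter).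

Compound 4 `NC1=NC2(CCOCC2)N(OCCCOc2ccc(Br)cc2)C(N)=N1` differs from compound 1 as follows: 4-bromophenyl in place of 3,4-dichlorophenyl on an oxygen on a saturated carbon. For the measured compounds named here, two steps bear on this. The step of a 36-fold higher number from compound 1 to compound 2 (1.56 log units; beyond the scatter) shows that a single halogen placed as 4-fluorophenyl, in place of 3,4-dichlorophenyl, costs a great deal; the step of a 2.3-fold lower number from compound 1 to compound 3 (0.35 log units; beyond the scatter) shows that a single bromine placed as 3-bromophenyl gives a modest gain. Compound 4 carries a single bromine, but in the 4-bromophenyl pattern, for which no direct comparison exists. The expectation is therefore a higher number than compound 1, of a size between those two steps, as a 4.4-fold higher number from compound 1 to compound 4 (0.65 log units; beyond the scatter). Compound 4 is estimated at 400 nM, with a range from 80 nM to 2000 nM.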

Compound 4, half-maximal inhibitory concentration: 320 nM
Estimate against measurement, compound 4: 1.3-fold (0.10 log units) above; the measured number falls inside the stated range.
By their numbers in this assay, from the lowest: compound 3; then compound 1; then compound 4; then compound 2.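

Exchanging 3-bromophenyl for 4-bromophenyl gives an 8.0-fold higher number from compound 3 to compound 4 (0.90 log units; beyond the scatter) in this assay, so with the same single halogen, the ring pattern alone changes the reading. With the pattern held, bromo in place of fluoro on an aromatic carbon gives a 10-fold lower number from compound 2 to compound 4 (1.01 log units; beyond the scatter), so the identity of the halogen also matters. The exchange of 3,4-dichlorophenyl for 4-bromophenyl gives a 3.6-fold higher number from compound 1 to compound 4 (0.55 log units; beyond the scatter), but it changes both the halogen and the number of halogens, so this step cannot be assigned to either change.

Going by these compounds, how 3-fluorophenyl, or a nitrile on the ring, would read remains open, as does whether these gaps persist with a longer chain on the oxygen. Nothing available here accounts for the differences.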